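The source may report more compounds than this note shows. Statements on the series, on what has been measured and on what is new or still open speak of the compounds shown alone.

Measured compounds in a functional assay on MCF7 cells (Homo sapiens) for antiproliferative activity, read by MTT assay, with a stated time of 48 h; on this read-out lower numbers stand for stronger inhibition and higher numbers for weaker inhibition:
- compound 1, `O=c1cc(-c2ccccc2)c2c(O)cc(I)cc2o1`, gives 25000 nM
- compound 2, `Cc1cc(=O)oc2cc(I)cc(O)c12`, gives 18300 nM
- compound 3, `O=c1cc(-c2ccccc2)c2c(O)cc(-c3cc4ccccc4s3)cc2o1`, gives 7600 nM

Among these three, compound 3 has the lowest number, with compound 2 nearest and compound 1 furthest, both separated from it by more than the scatter. The two steps that reach it are a 3.3-fold lower number from compound 1 to compound 3 (0.52 log units; beyond the scatter), which accounts for the position of compound 3, and a 1.4-fold lower number from compound 1 to compound 2 (0.14 log units; within the scatter), which hardly moves the number.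

Compound 4, `CCCc1cc(=O)oc2cc(-c3cc4ccccc4s3)cc(O)c12`, differs from compound 3 by a single change: propyl in place of phenyl on an aromatic carbon. Among the measured compounds shown here, the only measured step that speaks to this change is a 1.4-fold lower number from compound 1 to compound 2 (0.14 log units; within the scatter), where a small alkyl group replaced the same phenyl at the same position and the number stayed within the scatter. Propyl is a longer chain than methyl, but nothing in the measured set separates the two. The expectation in this assay is therefore a step of no size beyond the scatter, a 1.2-fold lower number from compound 3 to compound 4 (0.07 log units; within the scatter). Compound 4 is estimated at 6500 nM, with a range from 2500 nM to 16000 nM.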

Compound 4, half-maximal inhibitory concentration: 22300 nM
The estimate for compound 4 lay 3.4-fold (0.54 log units) below the measured number, and the stated range ends below it.
By their numbers in this assay, from the lowest: compound 3; then compounds 2, 4 and 1 (each within the scatter of the next).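

In this assay, propyl in place of phenyl on this aromatic carbon, opposite the ring oxygen, gives a step beyond the scatter when 1-benzothiophen-2-yl is on the core: a 2.9-fold higher number from compound 3 to compound 4 (0.47 log units; beyond the scatter). The earlier exchange at this carbon, methyl for phenyl with iodo on the core, gave only a 1.4-fold lower number from compound 1 to compound 2 (0.14 log units; within the scatter), so the outcome of replacing phenyl here is not the same in every setting, and it varies with the incoming alkyl group, the other substituent, or both. Nothing available explains this step.

On these data alone, it remains open whether methyl would behave like propyl alongside 1-benzothiophen-2-yl, and whether propyl would leave the number unchanged alongside iodo. As far as these compounds go, the effect of a longer chain, or of an amine at the end of the propyl chain, on this carbon also remains open.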